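The compounds below may be only part of what the source reports. "The series", "measured", "known", "first", "only" and "open" are said of these compounds alone.

Compound 1 `CCN1CCc2c(sc(NC(=O)[C@@H]3CCCN3)c2C(N)=O)C1`: in a functional assay (strain AB) with Danio rerio as the target, read by microscopy, with a stated time of 1 h (a higher number here means that more compound is needed for the effect, a lower number that less compound is needed), compound 1 gives > 25000 nM, which is a limit of the assay.
Compound 2 `CCN1CCc2c(sc(NC(=O)Nc3ccc(I)cc3)c2C(N)=O)C1`: in this assay compound 2 gives 1620 nM.
Compound 3 `CCN1CCc2c(sc(NC(=O)c3ccccc3)c2C(N)=O)C1`: in this assay compound 3 gives > 25000 nM, which is a limit of the assay.

For the measured compounds named here, compound 2 stands as the only real number in this assay; the other two compounds sit at the limit of > 25000 nM in this assay, at which 2 of the 3 values shown sit. Compound 4 `CCN1CCc2c(sc(NC(=O)Nc3cccc(C#N)c3)c2C(N)=O)C1` differs from compound 2 by 3-cyanophenyl in place of 4-iodophenyl on an amide-type nitrogen.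

Going by the values given here, no measured step alters a substituent within the aryl part of the urea. Among the compounds with values here, the steps of an at least 15-fold lower number from compound 1 to compound 2 (1.18 log units; beyond the scatter) and an at least 15-fold higher number from compound 2 to compound 3 (1.18 log units; beyond the scatter) show only that the group on the carbonyl carbon moves the number strongly, and both favour the (4-iodophenyl)amino group. The change to compound 4 keeps the urea and swaps only the aryl substitution, so a modest step towards a higher number is expected, a 2.8-fold higher number from compound 2 to compound 4 (0.44 log units; beyond the scatter), with real risk of a limit. Compound 4 is estimated at 4500 nM, range 1200 nM to 25000 nM.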

Compound 4, half-maximal effective concentration: 10300 nM
Estimate against measurement, compound 4: 2.3-fold (0.36 log units) below; measured number inside the range.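

With the urea kept, a 6.4-fold higher number from compound 2 to compound 4 (0.80 log units; beyond the scatter) shows that the aryl part alone moves the number in this assay and does so beyond the scatter. This change leaves compound 4 with a readable value, so the urea tolerates at least one swap of its aryl group without reaching the limit. Compound 1 and compound 3 stay at a limit of the assay, not a number: the limit of > 25000 nM in this assay, at which 2 of the 4 values shown sit.

Iodine is lost, a nitrile enters and the substituent's ring position changes in the same step, so these remain inseparable. A 3-iodophenyl or 4-cyanophenyl group would be needed to separate them.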